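Swapping a Pyridine Ring for a Furan on a Shared Core

This account rests on a few compounds, and the source may have more. Where it says the series, first, only, none or still open, it means among the compounds named here.

Three compounds sharing the same core have been examined in a functional assay on T47D cells (Homo sapiens) for cytotoxicity, read by CCK-8 assay and cell counting, with a stated time of 2 days; on this read-out lower numbers stand for stronger inhibition and higher numbers for weaker inhibition. Compound 1 `Oc1cccc(-c2cc(-c3cccnc3)nc(-c3cccc(Cl)c3)c2)c1` carries a 3-chlorophenyl group and a pyridin-3-yl group on that core, and in this assay compound 1 is recorded as "not determined" (no result reported), so no number exists for it. Compound 2 `Oc1cccc(-c2cc(-c3cccnc3)nc(-c3ccccc3Cl)c2)c1` is likewise recorded in this assay as "not determined" (no result reported). Only compound 3 `Oc1cccc(-c2cc(-c3ccc(Cl)cc3)nc(-c3cccnc3)c2)c1`, which carries a 4-chlorophenyl group, has a result: in this assay compound 3 gives 18100 nM, a weak effect.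

Compound 4 `Oc1cccc(-c2cc(-c3cccc(Cl)c3)nc(-c3ccco3)c2)c1` differs from compound 1 in one place: furan-2-yl in place of pyridin-3-yl on an aromatic carbon. In words, furan-2-yl takes the place of pyridin-3-yl on an aromatic carbon next to the ring nitrogen of the core.

Compound 1 has no number. The size of the step to compound 4 therefore cannot be measured from the data. Going by the values given here, the only anchor is compound 3, whose weak activity suggests that compounds act at high concentrations in this assay. The expectation is therefore for no step beyond the usual scatter, with compound 4 likely to sit near the weak end.

Compound 4 is estimated to give about 20000 nM in this assay, with a likely range from 5000 nM to 80000 nM.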

Compound 4, half-maximal inhibitory concentration: 3570 nM
Estimate against measurement, compound 4: 5.6-fold (0.75 log units) above, and the stated range ends above it.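

Going by these compounds alone, compound 1 has no number in this assay, so no step from it to compound 4 can be read, and the 3570 nM of compound 4 stands without a partner. Open, as far as these compounds go, is whether furan-2-yl in place of pyridin-3-yl strengthens, weakens or leaves unchanged the effect on these cells. Nothing available explains the value of compound 4.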